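This account rests on a few compounds, and the source may have more. Where it says the series, first, only, none or still open, it means among the compounds named here.

Compound 1 `O/N=C(/CCN1CCN(c2ccccn2)CC1)c1ccccc1Cl`: 25 nM
Compound 2 `O/N=C(\CCN1CCN(c2ccccn2)CC1)c1cccc(F)c1`: 17.1 nM

Both were tested in a functional assay on HEK293 cells with D(4) dopamine receptor (Homo sapiens) as the target, read by FLIPR; a higher number here means that more compound is needed for the effect, a lower number that less compound is needed. Compound 2 has the lowest of the two numbers, but compound 1 lies within the usual scatter, so the two cannot be told apart. Compound 3 `O/N=C(\CCN1CCN(c2ccccn2)CC1)c1ccc(F)cc1F` has not yet been measured. It differs from compound 2 by 2,4-difluorophenyl in place of 3-fluorophenyl on a carbon with a double bond to nitrogen. Within the data shown here, no measured pair shows a step of this kind. Compound 1 carries a different ring at the same place and gives 25 nM, close to compound 2, so the step of a 1.2-fold higher number from compound 2 to compound 3 (0.07 log units; within the scatter) is expected to stay within the scatter. Compound 3 is estimated at 20 nM, between 7 nM and 60 nM.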

Compound 3, half-maximal effective concentration: 8.9 nM
Compound 3: the middle estimate sits 2.2-fold (0.35 log units) above what was measured; low and high end bracket the measured number.
By their numbers in this assay, from the lowest: compounds 3, 2 and 1 (each within the scatter of the next, the first and the last beyond it).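

In this assay, among these compounds, placing 2,4-difluorophenyl where 3-fluorophenyl stood gives a 1.9-fold lower number from compound 2 to compound 3 (0.28 log units; within the scatter) and is the first reading of a single change at this position. The ring on this carbon can therefore carry a second fluorine and still give a number that cannot be told apart from that of compound 2. No measurement shown here offers an explanation for this result.

From the compounds shown here alone, whether a methoxy group or an amine on this ring would also stay within the scatter remains open. So does whether any group at this position can produce a step beyond it.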